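Second chloro on two isomeric cores: working notes

The compounds below may be only part of what the source reports. "The series", "measured", "known", "first", "only" and "open" are said of these compounds alone.

Compound 1 `ClCc1cccc(Cn2cnc3ncnc(Cl)c32)c1` and compound 2 `ClCc1cccc(Cn2cnc3c(Cl)ncnc32)c1` are built from the same atoms joined differently; the difference between the two cores is not broken down here. In a functional assay on EKVX cells (Homo sapiens) for cytotoxicity, read by sulforhodamine B assay, with a stated time of 48 h (on this read-out lower numbers stand for stronger inhibition of growth and higher numbers for weaker inhibition of growth), compound 1 gives 29500 nM and compound 2 gives 33900 nM, values within the usual scatter of each other. Compound 3 `ClCc1cccc(Cn2cnc3c(Cl)nc(Cl)nc32)c1` carries chloro in place of hydrogen on an aromatic carbon relative to compound 2. In this assay compound 3 gives 2310 nM, which is a 15-fold lower number from compound 2 to compound 3 (1.17 log units; beyond the scatter). Compound 4 `ClCc1cccc(Cn2cnc3nc(Cl)nc(Cl)c32)c1` carries the same change relative to compound 1, namely (chloro in place of hydrogen on an aromatic carbon), at a place described in identical words. Going by the values given here, the only measured example of this change is a 15-fold lower number from compound 2 to compound 3 (1.17 log units; beyond the scatter), and it is the sole basis available. The expected step is therefore a 13-fold lower number from compound 1 to compound 4 (1.11 log units; beyond the scatter), matched in size to that example. Compound 4 is estimated at 2300 nM, with a likely range from 800 nM to 8000 nM.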

Compound 4, concentration for total growth inhibition: 2130 nM
Compound 4: middle estimate off by 1.1-fold (0.03 log units), on the high side; low and high end bracket the measured number.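

In this assay the added chloro gives a 14-fold lower number from compound 1 to compound 4 (1.14 log units; beyond the scatter), and this matches the earlier step on the other core: the same change on two cores in this assay, a 15-fold lower number (1.17 log units; beyond the scatter) from compound 2 to compound 3 and a 14-fold lower number (1.14 log units; beyond the scatter) from compound 1 to compound 4, 1.1-fold (0.03 log units) apart, within the scatter of two such steps The change therefore carried over in size across these two isomeric cores, at a place described in identical words on each. This rests on two matched pairs in one cell line, so it gives no rule for other cores in the series and no explanation of the size of the step.

The compounds shown leave open whether an amine, a methoxy group or a longer chain in place of the added chloro would give a step of similar size. On these data alone, whether the step persists when the chloromethyl group is replaced also remains open.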